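This account rests on a few compounds, and the source may have more. Where it says the series, first, only, none or still open, it means among the compounds named here.

Measured in a functional assay on A-431 cells (Homo sapiens) for antiproliferative activity, read by MTT assay, with a stated time of 72 h; on this read-out higher numbers stand for weaker inhibition and lower numbers for stronger inhibition: compound 1 `COc1cc2ncnc(Nc3cccc(Cl)c3)c2cc1OCCCCC(=O)Nc1ccc(S(N)(=O)=O)cc1` gives 30400 nM. Compound 2 `COc1cc2ncnc(Nc3ccc(Br)cc3)c2cc1OCCCCC(=O)Nc1ccc(S(N)(=O)=O)cc1` gives 6570 nM. Compound 3 `COc1cc2ncnc(Nc3ccc(F)c(Br)c3)c2cc1OCCCCC(=O)Nc1ccc(S(N)(=O)=O)cc1` gives 8020 nM.

Compound 3 stands second highest of the three numbers; its nearest neighbour is compound 2, a 1.2-fold higher number from compound 2 to compound 3 (0.09 log units; within the scatter), and its furthest is compound 1, a 3.8-fold lower number from compound 1 to compound 3 (0.58 log units; beyond the scatter).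

Compound 4 `COc1cc2ncnc(Nc3cccc(C)c3)c2cc1OCCCCC(=O)Nc1ccc(S(N)(=O)=O)cc1` differs from compound 3 by 3-methylphenyl in place of 3-bromo-4-fluorophenyl on a nitrogen on an aromatic ring. Within the data shown here, the steps that bear on this are a 3.8-fold lower number from compound 1 to compound 3 (0.58 log units; beyond the scatter) and a 4.6-fold lower number from compound 1 to compound 2 (0.67 log units; beyond the scatter), where replacing 3-chlorophenyl by a bromo-bearing phenyl lowered the number modestly. A 3-methylphenyl resembles the 3-chlorophenyl of compound 1 more than the bromo-bearing phenyls, so a modest rise in this assay is expected, a 2.0-fold higher number from compound 3 to compound 4 (0.30 log units; within the scatter). Compound 4 is estimated at 16000 nM, with a range of 5000 nM to 50000 nM.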

Compound 4, half-maximal inhibitory concentration: 7460 nM
For compound 4 the middle estimate is 2.1-fold (0.33 log units) above the measured one; measured number inside the range.
By their numbers in this assay, from the lowest: compounds 2, 4 and 3 (each within the scatter of the next); then compound 1.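

In this assay, 3-methylphenyl on a nitrogen on an aromatic ring reads level with both bromo-bearing phenyls (a 1.1-fold lower number from compound 3 to compound 4 (0.03 log units; within the scatter); a 1.1-fold higher number from compound 2 to compound 4 (0.06 log units; within the scatter)), so among these compounds bromine is not required for this level. Methyl in place of chloro on an aromatic carbon gives a clear step (a 4.1-fold lower number from compound 1 to compound 4 (0.61 log units; beyond the scatter)), which leaves compound 1 apart from the other three. Nothing measured here offers an explanation for this difference.

As far as these compounds go, whether a trifluoromethyl or an amine in that place would read with methyl or with chloro stays open. From the compounds shown here alone, how a longer chain would affect these readings also stays open.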